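Fluorine on the phenyl of a piperazine acetamide

The compounds below may be only part of what the source reports. "The series", "measured", "known", "first", "only" and "open" are said of these compounds alone.

Measured compounds in a functional assay, read by spectrophotometry, with a stated time of 30 min, tested at 50 ug/mL; a lower number here means a weaker effect, a higher number a stronger effect of the compound at the concentration tested:
compound 1, `CN1CCN(CC(=O)Nc2nc3ccccc3[nH]2)CC1`, 33.5%
compound 2, `CCN1CCN(CC(=O)Nc2nc3ccccc3[nH]2)CC1`, 35.7%
compound 3, `O=C(CN1CCN(c2ccccc2)CC1)Nc1nc2ccccc2[nH]1`, 24.1%

Compound 3 has the lowest of the three numbers in this assay. Its nearest neighbour is compound 1, and the change there is a number 9.4 percentage points lower from compound 1 to compound 3 (within the scatter). The step of a number 11.6 percentage points lower from compound 2 to compound 3 (beyond the scatter) is the only one that reaches beyond the scatter, while a number 2.2 percentage points higher from compound 1 to compound 2 (within the scatter) stays within it.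

Compound 4, `O=C(CN1CCN(c2ccccc2F)CC1)Nc1nc2ccccc2[nH]1`, differs from compound 3 by fluoro in place of hydrogen on an aromatic carbon. Among the compounds with values here, none of the measured steps touches this aromatic ring; the steps above concern what sits on the amine nitrogen in the ring, not a substituent on the phenyl. There is therefore nothing in the measured set that points to a step beyond the scatter in this assay for this change, in either direction. Compound 4 is expected to give about 25%, with a range of 14% to 38%. The step this estimate implies, a number 0.9 percentage points higher from compound 3 to compound 4 (within the scatter), is expected to stay within the scatter.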

Compound 4, a percentage reported as activity, at one concentration (the size of the read-out at that concentration, not a potency): 37.4%
For compound 4 the middle estimate is 12.4 percentage points below the measured one; the range from low to high includes it.
By their numbers in this assay, from the lowest: compounds 3, 1, 2 and 4 (each within the scatter of the next, the first and the last beyond it).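

In this assay the phenyl ring responds to a single substitution, with a number 13.3 percentage points higher from compound 3 to compound 4 (beyond the scatter) for fluoro in place of hydrogen on an aromatic carbon, ortho to a large group. With 2-fluorophenyl on the amine nitrogen, a number 1.7 percentage points higher from compound 2 to compound 4 (within the scatter) against the ethyl compound and a number 3.9 percentage points higher from compound 1 to compound 4 (within the scatter) against the methyl compound, so the gap that plain phenyl showed against ethyl does not appear with this group. Nothing at hand accounts for what this one fluorine does.

As far as these compounds go, it remains open whether this result is particular to fluoro or would also appear with chloro, methoxy or a nitrile on the same carbon. Also open, from the compounds shown here alone, is whether fluoro on another carbon of the phenyl would give a step of the same size.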